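A few compounds are considered here, and "the series" means these few. Any claim that something is new, unique, unknown or untested is made for them only; others in the source may bear on it.

Compound 1 `Nc1nc2cc(Cl)c(Cl)cc2n1Cc1ccc(Cl)cc1` and compound 2 `Cc1ccc(Cn2c(N)nc3cc(Cl)c(Cl)cc32)cc1` share a core and differ only at one aromatic carbon of the pendant ring. In a functional assay on CEM-SS cells (Homo sapiens) for cytotoxicity (a lower number here means a stronger inhibitor, a higher number a weaker inhibitor), compound 1 gives 32000 nM, and compound 2 gives 40000 nM. Among the measured compounds shown here, the single step between them, a 1.3-fold higher number from compound 1 to compound 2 (0.10 log units; within the scatter), shows that exchanging a chloro for a methyl at that position leaves the number essentially where it was.

Compound 3 `Nc1nc2cc(Cl)c(Cl)cc2n1Cc1ccc(Cl)c(Cl)c1` is not yet measured. It differs from compound 1 by chloro in place of hydrogen on an aromatic carbon. For the measured compounds named here, no measured step adds a group to this ring; the only step available, from compound 1 to compound 2, swaps one group for another and stays within the scatter. On that basis the added chloro is expected to bring no step beyond the scatter, and the estimated step is a 1.3-fold lower number from compound 1 to compound 3 (0.11 log units; within the scatter). Compound 3 is therefore expected to give about 25000 nM in this assay, with a range from 10000 nM to 60000 nM.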

Compound 3, half-maximal inhibitory concentration: 30000 nM
Estimate against measurement, compound 3: 1.2-fold (0.08 log units) below; the measured number falls inside the stated range.
By their numbers in this assay, from the lowest: compounds 3, 1 and 2 (each within the scatter of the next).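

Among the compounds shown here, the earlier pair showed only one group exchanged for another on that ring, whereas compound 3 adds a chloro group at a carbon that carried hydrogen, ortho to a chloro group, and in this assay this gives a 1.1-fold lower number from compound 1 to compound 3 (0.03 log units; within the scatter). At this position, then, a second chloro group on the ring leaves the number where it was, so adding a heavy atom here, like the earlier exchange of chloro for methyl, produces no step beyond the scatter.

From the compounds shown here alone, whether a different group at this carbon, such as a methoxy group, a carboxylic acid or a longer chain, would move the number beyond the scatter stays open. Going by these compounds, the shared core is the same in all three compounds, so what changes there would do also stays open. Nothing available explains why this added chloro group leaves the number unchanged.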